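This account rests on a few compounds, and the source may have more. Where it says the series, first, only, none or still open, it means among the compounds named here.

Compound 1 `CN1CCN(C(=O)Cn2c(=O)c3c(ncn3C)n(C)c2=O)CC1`: 8.6%
Compound 2 `Cn1cnc2c1c(=O)n(CC(=O)N1CCN(c3ccccc3)CC1)c(=O)n2C`: 4.6%

In a functional assay on MGC-803 cells (Homo sapiens) for inhibition, read by MTT assay, with a stated time of 48 h, tested at 20 uM (a lower number here means less inhibition, a higher number more inhibition at the concentration tested (going by the name of the read-out)), compound 1 gives 8.6%, while compound 2 gives 4.6%. Compound 2 holds the lowest of the two numbers, its nearest neighbour being compound 1, and the step of a number 4 percentage points lower from compound 1 to compound 2 (within the scatter) lies within the scatter. Compound 3 `Cn1cnc2c1c(=O)n(CC(=O)N1CCN(C(=O)OC(C)(C)C)CC1)c(=O)n2C` differs from compound 2 by tert-butoxycarbonyl in place of phenyl on an amine nitrogen in a ring. Going by the values given here, the only measured step bearing on this position, a number 4 percentage points lower from compound 1 to compound 2 (within the scatter), showed no change beyond the scatter. Compound 3 is therefore expected to show a number 1.4 percentage points higher from compound 2 to compound 3 (within the scatter). The estimate for compound 3 is 6%, ranging from -5% to 18%.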

Compound 3, a percentage reported as inhibition, at one concentration (the size of the read-out at that concentration, not a potency): 20%
Compound 3: the middle estimate sits 14 percentage points below what was measured, and the stated range ends below it.
By their numbers in this assay, from the lowest: compounds 2 and 1 (each within the scatter of the next); then compound 3.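

At the amine nitrogen in the ring, the group can change the reading in this assay, which the methyl and phenyl pair did not show. Tert-butoxycarbonyl in place of phenyl gives a number 15.4 percentage points higher from compound 2 to compound 3 (beyond the scatter) and in place of methyl gives a number 11.4 percentage points higher from compound 1 to compound 3 (beyond the scatter), so this group stands apart from both. Nothing available explains this rise.

The compounds shown leave open whether the carbonyl or the tert-butyl part goes with the higher number. An acetyl or ethoxycarbonyl group on the same nitrogen would separate the two.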